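This account rests on a few compounds, and the source may have more. Where it says the series, first, only, none or still open, it means among the compounds named here.

In a functional assay on ZR-75-1 cells (Homo sapiens) for inhibition, read by sulforhodamine B assay (a lower number here means a stronger inhibitor of growth, a higher number a weaker inhibitor of growth), compound 3 `Oc1cccc2[nH]c(-c3ccc(-c4ccc(-c5ccc(C(F)(F)F)cc5)cc4)cc3)nc12` gives 5110 nM and stands second highest of the three numbers. Compound 1 `COc1cc(-c2ccc(-c3ccc(-c4nc5cc(C)ccc5[nH]4)cc3)cc2)cc(OC)c1OC` gives 190 nM as the lowest number and compound 2 `FC(F)(F)c1ccc(-c2ccc(-c3ccc(-c4nc5ccccc5[nH]4)cc3)cc2)cc1` gives 48300 nM as the highest. Compound 4 `COc1ccc(-c2ccc(-c3ccc(-c4nc5c(O)cccc5[nH]4)cc3)cc2)cc1OC` follows from compound 3 through 3,4-dimethoxyphenyl in place of 4-(trifluoromethyl)phenyl on an aromatic carbon with 3,4-dimethoxyphenyl in place of 4-(trifluoromethyl)phenyl. For the measured compounds named here, the only measured step is a 9.5-fold lower number from compound 2 to compound 3 (0.98 log units; beyond the scatter) for hydroxy in place of hydrogen, a different change, and compound 4 keeps that hydroxy. Going by the values given here, no measured step isolates the present change. Compound 1 also carries methoxy groups and its 190 nM is the sole hint, though it differs elsewhere too. A lower number is therefore expected, with an estimated 5.7-fold lower number from compound 3 to compound 4 (0.75 log units; beyond the scatter) of moderate size. Compound 4 is expected at 900 nM (estimated range 200 nM to 4000 nM).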

Compound 4, concentration for 50% growth inhibition: 2110 nM
The estimate for compound 4 lay 2.3-fold (0.37 log units) below the measured number; the measured number falls inside the stated range.
By their numbers in this assay, from the lowest: compound 1; then compound 4; then compound 3; then compound 2.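

In this assay, for the compounds shown here, replacing 4-(trifluoromethyl)phenyl with 3,4-dimethoxyphenyl gives a 2.4-fold lower number from compound 3 to compound 4 (0.38 log units; beyond the scatter), the first measured step at this position, para to a large group. With the hydroxy kept in both compounds, the step shows that this aryl group alone shifts growth inhibition, though only modestly. Nothing available accounts for the shift.

As far as these compounds go, whether either methoxy alone would produce this step, and whether it would persist without the hydroxy, remains open. So does the effect of an amine or a carboxylic acid on this ring.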